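A few compounds are considered here, and "the series" means these few. Any claim that something is new, unique, unknown or untested is made for them only; others in the source may bear on it.

In an ADME assay on NIH3T3 cells (Mus musculus) for antiproliferative activity, read by sulforhodamine B assay, with a stated time of 48 h (a higher number here means a weaker inhibitor, a lower number a stronger inhibitor), compound 1 `C[C@H]1N=C2C[C@H]3C[C@H](C3(C)C)[C@@]2(C)OC1=O` gives > 1800000 nM, which is a limit of the assay and not a number. Its mirror image, compound 2 `C[C@@H]1N=C2C[C@@H]3C[C@@H](C3(C)C)[C@]2(C)OC1=O`, gives > 2000000 nM, which is also a limit. Compound 2 therefore offers only a limit as a starting point. Compound 3 `CC(C)(C)OC(=O)CC[C@@H]1N=C2C[C@@H]3C[C@@H](C3(C)C)[C@]2(C)OC1=O` keeps the core of compound 2 but gains a chain: (tert-butoxycarbonyl)methyl in place of hydrogen on a saturated chain carbon bound to a saturated ring carbon, with (tert-butoxycarbonyl)methyl in place of hydrogen on a saturated chain carbon bound to a saturated ring carbon. For the measured compounds named here, the only measured step is a step that the two limits leave unreadable from compound 1 to compound 2, and it rests on (the fact that compounds 1 and 2 differ only in the configuration as drawn), so it gives no guide to the effect of adding a chain. Inhibition in this assay is therefore expected to stay weak, with only a cautious allowance for stronger inhibition, and the expected change is an at least 4.0-fold lower number from compound 2 to compound 3 (0.60 log units; beyond the scatter). The estimate for compound 3 is 500000 nM, with an expected range of 100000 nM to 2000000 nM.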

Compound 3, half-maximal inhibitory concentration: > 1000000 nM
Compound 3: a limit, no number; the forecaster's own chance of this, stated with the estimate: 50%; at least 2.0-fold (0.30 log units) between middle value and limit.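

In this assay compound 3 gives > 1000000 nM, which is a limit and not a number. Compound 2 also stands only at a limit, so the step between compound 2 and compound 3 cannot be read. The compounds shown leave open whether (tert-butoxycarbonyl)methyl changes the inhibition at all, and how strongly any of the three compounds inhibits.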